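This account rests on a few compounds, and the source may have more. Where it says the series, first, only, none or still open, it means among the compounds named here.

Measured so far in an ADME assay on L929 cells (Mus musculus) for cytotoxicity, read by resazurin assay, with a stated time of 48 h; a lower number here means that less compound is tolerated, a higher number that more compound is tolerated:
- compound 1, `C=Cn1c2ccc([N+](=O)[O-])cc2c(=O)n1Cc1ccccc1`: 160000 nM
- compound 2, `C=CCn1c2ccc([N+](=O)[O-])cc2c(=O)n1Cc1ccccc1`: 192000 nM
- compound 3, `COC(=O)Cn1c2ccc([N+](=O)[O-])cc2c(=O)n1Cc1ccccc1`: 129000 nM

Compound 1 stands second highest of these three numbers, with compound 2 the nearest and compound 3 the furthest, both within the scatter of it. Compound 4, `CCOC(=O)CCCn1c2ccc([N+](=O)[O-])cc2c(=O)n1Cc1ccccc1`, differs from compound 1 in one place: 3-(ethoxycarbonyl)propyl in place of vinyl on an aromatic nitrogen. Among the measured compounds shown here, the steps that bear on this are a 1.2-fold higher number from compound 1 to compound 2 (0.08 log units; within the scatter) and a 1.2-fold lower number from compound 1 to compound 3 (0.09 log units; within the scatter), both within the scatter; the related step of a 1.5-fold lower number from compound 2 to compound 3 (0.17 log units; within the scatter) is also within the scatter. Nothing among these swaps at the same aromatic nitrogen moved this assay beyond its scatter, so no step beyond the scatter is expected for compound 4 either, as a 1.1-fold lower number from compound 1 to compound 4 (0.03 log units; within the scatter). Compound 4 is therefore estimated at 150000 nM, with a range from 75000 nM to 300000 nM.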

Compound 4, concentration lethal to 50% of the cells: 78100 nM
Beside the measured number, compound 4's estimate is 1.9-fold (0.28 log units) above it; measured number inside the range.
By their numbers in this assay, from the lowest: compounds 4, 3, 1 and 2 (each within the scatter of the next, the first and the last beyond it).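

Among the compounds shown here, at this aromatic nitrogen, 3-(ethoxycarbonyl)propyl is the first swap to move this assay beyond the scatter, with less compound tolerated: the modest steps are a 2.0-fold lower number from compound 1 to compound 4 (0.31 log units; beyond the scatter) and a 2.5-fold lower number from compound 2 to compound 4 (0.39 log units; beyond the scatter) in this series. Set against the (methoxycarbonyl)methyl group, the change stays within the scatter, with a 1.7-fold lower number from compound 3 to compound 4 (0.22 log units; within the scatter) as the step, so those two compounds cannot be separated here. No available evidence bears on this shift.

On these data alone, whether the longer chain or its ester end matters remains open. A carboxylic acid or an amine at the end of the same chain, or a plain butyl chain, could help separate the two.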